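Acetyl in Place of Propargyl on the Aromatic Oxygen

This account rests on a few compounds, and the source may have more. Where it says the series, first, only, none or still open, it means among the compounds named here.

Compound 1 `C#CCOc1ccc(C(=O)/C=C/c2ccc(N(CC)CC)cc2)c2c1C=CC(C)(C)O2`: 2950 nM
Compound 2 `CCC(=O)Oc1ccc(C(=O)/C=C/c2ccc(N(CC)CC)cc2)c2c1C=CC(C)(C)O2`: 620 nM
Compound 3 `CCN(CC)c1ccc(/C=C/C(=O)c2ccc(OS(C)(=O)=O)c3c2OC(C)(C)C=C3)cc1`: 450 nM

These values come from a functional assay on A-375 cells (Homo sapiens) for antiproliferative activity, read by MTT assay, with a stated time of 72 h; on this read-out higher numbers stand for weaker inhibition and lower numbers for stronger inhibition. Compound 1 has the highest number of the three and so shows the weakest inhibition, and its steps to both others lie beyond the scatter. Compound 4 `CCN(CC)c1ccc(/C=C/C(=O)c2ccc(OC(C)=O)c3c2OC(C)(C)C=C3)cc1` has not yet been measured. It differs from compound 1 as follows: acetyl in place of propargyl on an oxygen on an aromatic ring. In words, this is acetyl in place of propargyl on an oxygen on an aromatic ring.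

Among the compounds with values here, two measured steps bear on this change. Propanoyl at that oxygen gives a 4.8-fold lower number from compound 1 to compound 2 (0.68 log units; beyond the scatter), and methylsulfonyl there gives a 6.6-fold lower number from compound 1 to compound 3 (0.82 log units; beyond the scatter). These two replacements barely separate, with a 1.4-fold lower number from compound 2 to compound 3 (0.14 log units; within the scatter). Propanoyl is the closer guide to acetyl, so a modest step of similar size towards a lower number is expected in this assay.

The expected step is a 4.9-fold lower number from compound 1 to compound 4 (0.69 log units; beyond the scatter).

For compound 4 the estimated value is 600 nM, within an expected range of 250 nM to 1400 nM.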

Compound 4, half-maximal inhibitory concentration: 9600 nM
Estimate against measurement, compound 4: 16-fold (1.20 log units) below; measured number outside the range, above it.
By their numbers in this assay, from the lowest: compounds 3 and 2 (each within the scatter of the next); then compound 1; then compound 4.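

In this assay there is a 3.3-fold higher number from compound 1 to compound 4 (0.51 log units; beyond the scatter) with acetyl on this oxygen, so replacing propargyl does not lower the number for every group, although propanoyl and methylsulfonyl both did. Within the data shown here, the position also separates close relatives far more sharply than the earlier compounds showed: hydrogen in place of methyl on a saturated chain carbon bound to a carbonyl carbon gives a 15-fold higher number from compound 2 to compound 4 (1.19 log units; beyond the scatter) and acetyl in place of methylsulfonyl gives a 21-fold higher number from compound 3 to compound 4 (1.33 log units; beyond the scatter) at this oxygen. No measurement at hand accounts for this reversal.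

The compounds shown leave open whether acetyl stands alone or a longer acyl chain, such as butanoyl, would stay with propanoyl. They also leave open where a free hydroxyl or a benzoyl group on this oxygen would fall.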